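Pivalamide to acetamide on the pyridine: expected shift

The source may hold more compounds than are shown below. What is called first, only, known or untested is meant among the compounds shown, and "the series" means these compounds.

Among the compounds with values here, compound 1 `CC(C)(C)C(=O)Nc1ccc(-c2ccc(C(=O)N[C@H]3CN[C@@H](C(=O)Nc4ccc(Cl)c(C(F)(F)F)c4)C3)cc2)cn1` gives 11600 nM in a functional assay on K562 cells (Homo sapiens) for inhibition, read by MTT assay, with a stated time of 48 h (on this read-out higher numbers stand for weaker inhibition and lower numbers for stronger inhibition), the highest of the two numbers so far. Compound 2 `C[C@H](NC(=O)c1cccc(-c2ccc(NS(C)(=O)=O)nc2)c1)C(=O)Nc1ccc(Cl)c(C(F)(F)F)c1` gives 4660 nM in this assay, a lower number than compound 1 and a gap beyond the usual scatter. Compound 3 `CC(=O)Nc1ccc(-c2ccc(C(=O)N[C@H]3CN[C@@H](C(=O)Nc4ccc(Cl)c(C(F)(F)F)c4)C3)cc2)cn1` is not yet measured. Compound 3 differs from compound 1 by methyl in place of tert-butyl on a carbonyl carbon. Within the data shown here, no measured pair shows this change, so only a small step, if any, in either direction is expected, a 1.2-fold lower number from compound 1 to compound 3 (0.06 log units; within the scatter). For compound 3 the expected value in this assay is 10000 nM, with a range from 4000 nM to 30000 nM.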

Compound 3, half-maximal inhibitory concentration: 22800 nM
For compound 3 the middle estimate is 2.3-fold (0.36 log units) below the measured one; low and high end bracket the measured number.
By their numbers in this assay, from the lowest: compound 2; then compounds 1 and 3 (each within the scatter of the next).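

In this assay, within the data shown here, methyl in place of tert-butyl on a carbonyl carbon gives a 2.0-fold higher number from compound 1 to compound 3 (0.29 log units; within the scatter), the first reading of any change at this position. The acetamido and (tert-butyl)carbonylamino forms are therefore not separated by this read-out. No measurement at hand speaks to what lies behind this step.

From the compounds shown here alone, whether a longer chain, an amine or a carboxylic acid on this carbonyl carbon would move the number beyond the scatter remains open. Also open, going by these compounds, is whether the same change would behave alike on the core of compound 2.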